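A few compounds are considered here, and "the series" means these few. Any claim that something is new, unique, unknown or untested is made for them only; others in the source may bear on it.

Among the measured compounds shown here, in a functional assay on KB-VIN10 cells (Homo sapiens) for inhibition, with a stated time of 72 h (on this read-out higher numbers stand for weaker inhibition and lower numbers for stronger inhibition), three compounds on the shared core have measured values so far. Compound 2 (`COc1ccc(S(=O)(=O)N2CCc3cccc(-c4ccc(F)cc4)c32)cc1`) gives 94.6 nM, the lowest of the three. Compound 3 (`COc1ccc(S(=O)(=O)n2ccc3cccc(-c4ccc(F)cc4)c32)cc1`) is nearest to it at 202 nM, and compound 1 (`COc1ccc(S(=O)(=O)N2CCc3cccc(-c4cc(OC)c(OC)c(OC)c4)c32)cc1`) is furthest at 4670 nM. Both gaps lie beyond the usual scatter.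

Compound 4 (`COc1ccc(S(=O)(=O)N2CCc3cccc(-c4ccc(C#N)cc4)c32)cc1`) is still unmeasured. It departs from compound 2 in one place: cyano in place of fluoro on an aromatic carbon. This puts cyano in place of fluoro on an aromatic carbon, para to a large group. For the measured compounds named here, no measured pair isolates a change at this place, so the data give no direct guide to its size or direction. A modest move toward weaker inhibition in this assay is the working expectation, with the number rising slightly beyond the scatter. The estimated step is a 2.0-fold higher number from compound 2 to compound 4 (0.30 log units; within the scatter). The range is kept wide, as the three measured values already spread far, with compound 1 at 4670 nM. For compound 4 the expected value is 190 nM, with an estimated range of 55 nM to 700 nM.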

Compound 4, half-maximal inhibitory concentration: 29.2 nM
The estimate for compound 4 lay 6.5-fold (0.81 log units) above the measured number, outside the stated range (below it).
By their numbers in this assay, from the lowest: compound 4; then compound 2; then compound 3; then compound 1.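

In this assay, among the compounds shown here, the change from 4-fluorophenyl to 4-cyanophenyl gives a 3.2-fold lower number from compound 2 to compound 4 (0.51 log units; beyond the scatter), the first step that isolates a single place. At this aromatic carbon, para to a large group, fluoro is thus not the best of the groups shown: cyano, with one more heavy atom and a hydrogen-bond acceptor, goes with stronger inhibition. Nothing measured here shows which feature of the cyano group goes with this step.

On these data alone, it remains open whether the gain belongs to cyano alone or extends to other groups at this place, such as a carboxylic acid, an amine or an amide. As far as these compounds go, it is also open whether the same exchange gives a step of similar size on the core of compound 3.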